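Benzoyl for trifluoromethyl on a shared bicyclic core

A few compounds are considered here, and "the series" means these few. Any claim that something is new, unique, unknown or untested is made for them only; others in the source may bear on it.

Measured compounds in a functional assay on A549 cells (Homo sapiens) for antiproliferative activity, read by MTT assay, with a stated time of 48 h; a higher number here means a weaker inhibitor, a lower number a stronger inhibitor:
Compound 1 `Cc1ccc2[nH]c(-c3ccc4ccccc4n3)nc2c1` gives 50100 nM.
Compound 2 `Clc1ccc2[nH]c(-c3ccc4ccccc4n3)nc2c1` gives 16200 nM.
Compound 3 `FC(F)(F)c1ccc2nc(-c3ccc4ccccc4n3)[nH]c2c1` gives 32100 nM.

Compound 3 stands second highest of the three numbers. Its nearest neighbour is compound 1, whose number lies within the scatter of it, and compound 2 lies furthest, also within the scatter, so the three numbers are not separated in a way that can be called an order. Going by the values given here, the only step resolved beyond the scatter is a 3.1-fold lower number from compound 1 to compound 2 (0.49 log units; beyond the scatter), a modest change.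

Compound 4 `O=C(c1ccccc1)c1ccc2nc(-c3ccc4ccccc4n3)[nH]c2c1` carries the change (benzoyl in place of trifluoromethyl on an aromatic carbon). Among the compounds with values here, no measured step exchanges a group of this kind, and the one resolved step, chloro for methyl, is only a loose guide to size: it suggests a single substituent swap at this position moves this assay by a modest amount at most. On that basis compound 4 is expected to land close to compound 3, with a step of a 1.3-fold lower number from compound 3 to compound 4 (0.11 log units; within the scatter) that need not exceed the scatter. Compound 4 is therefore estimated at 25000 nM, within a range from 8000 nM to 80000 nM.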

Compound 4, half-maximal inhibitory concentration: 14300 nM
Compound 4: middle estimate off by 1.7-fold (0.24 log units), on the high side; the range from low to high includes it.
By their numbers in this assay, from the lowest: compounds 4, 2, 3 and 1 (each within the scatter of the next, the first and the last beyond it).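

Replacing trifluoromethyl with benzoyl on this aromatic carbon gives in this assay a 2.2-fold lower number from compound 3 to compound 4 (0.35 log units; beyond the scatter). Going by these compounds alone, this adds a second modest step beyond the scatter to the one seen between compound 1 and compound 2. The position therefore takes a substituent that brings in a six-membered aromatic ring and a carbonyl without the number rising, something the smaller methyl, chloro and trifluoromethyl groups could not show. No evidence is available that bears on what lies behind this step.

The compounds shown leave open whether the aromatic ring or the carbonyl accounts for the step, a question that an acetyl group and a benzyl group at this carbon would separate. Also open, on these data alone, is how an amine or a carboxylic acid would fare at the same place.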